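A few compounds are considered here, and "the series" means these few. Any claim that something is new, unique, unknown or untested is made for them only; others in the source may bear on it.

Measured so far:
compound 1 `CCCCCCCCCC(=O)O[C@H]1[C@H](O)[C@H](n2ccc(N)nc2=O)O[C@@H]1CO` gives 0.09 ug/mL
compound 2 `CCCCCCCCCC(=O)OC[C@H]1O[C@@H](n2ccc(N)nc2=O)[C@@H](O)[C@@H]1OC(=O)CCCCCCCCC` gives 0.11 ug/mL
compound 3 `CCCCCC(=O)O[C@H]1[C@H](O)[C@H](n2ccc(N)nc2=O)O[C@@H]1CO` gives 0.05 ug/mL

In a functional assay on HeLa cells (Homo sapiens) for cytotoxicity, read by cell counting, with a stated time of 48 h (a lower number here means that less compound is needed, a higher number that more compound is needed for the effect), compound 1 holds the second highest of the three numbers; its nearest neighbour is compound 2 (a 1.2-fold higher number from compound 1 to compound 2 (0.09 log units; within the scatter)), its furthest compound 3 (a 1.8-fold lower number from compound 1 to compound 3 (0.26 log units; within the scatter)). Compound 4 `CCCCCCCC/C=C\CCCCCCCCCCCC(=O)O[C@H]1[C@H](O)[C@H](n2ccc(N)nc2=O)O[C@@H]1CO` carries dodec-3-en-1-yl in place of hydrogen on a saturated chain carbon, nine bonds along the chain from a carbonyl carbon, a lengthening of the acyl chain on the shared core. Going by the values given here, two measured steps bear on it: the shortening of that same chain, a 1.8-fold lower number from compound 1 to compound 3 (0.26 log units; within the scatter), and the added ester, a 1.2-fold higher number from compound 1 to compound 2 (0.09 log units; within the scatter); both stayed within the scatter. Among these compounds, changing the chain has moved the number little, so for compound 4 no step beyond the scatter is expected, a 1.3-fold higher number from compound 1 to compound 4 (0.12 log units; within the scatter). Compound 4 is estimated at 0.12 ug/mL, with a range of 0.05 ug/mL to 0.3 ug/mL.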

Compound 4, concentration for half-maximal effect: 0.16 ug/mL
Compound 4: the middle estimate sits 1.3-fold (0.12 log units) below what was measured, and the stated range covers the measured number.
By their numbers in this assay, from the lowest: compounds 3, 1, 2 and 4 (each within the scatter of the next, the first and the last beyond it).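

In this assay, dodec-3-en-1-yl in place of hydrogen on a saturated chain carbon, nine bonds along the chain from a carbonyl carbon, gives a 1.8-fold higher number from compound 1 to compound 4 (0.25 log units; within the scatter), so this position accepts the added dodec-3-en-1-yl chain and its double bond without a step beyond the scatter. Still, compound 3 at 0.05 ug/mL and compound 4 at 0.16 ug/mL lie beyond the scatter of each other, so chain changes at this position are not without any reading. No measurement bears on why this is so. Open remain a saturated chain of the same length and an amine or a carboxylic acid on the acyl chain.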